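The compounds below may be only part of what the source reports. "The series", "measured", "known", "first", "only" and "open" are said of these compounds alone.

Compound 3 `O=C1COc2ccc(-c3cnc(Cl)c(NS(=O)(=O)c4ccc(F)cc4)c3)cc2N1` stands at the top of everything measured in a functional assay on HepG2 cells (Homo sapiens) for antiproliferative activity, read by MTT assay, with a stated time of 72 h; on this read-out higher numbers stand for weaker inhibition and lower numbers for stronger inhibition. In this assay compound 3 gives > 40000 nM, which is a limit of the assay and not a number. Its two close relatives stand the same way. Compound 1 `COc1cccc(N2C(=O)COc3ccc(-c4cnc(Cl)c(NS(=O)(=O)c5ccc(F)cc5)c4)cc32)c1` gives > 40000 nM, again only a limit. Compound 2 `O=C1COc2ccc(-c3cnc(Cl)c(NS(=O)(=O)c4ccc(F)cc4)c3)cc2N1c1ccc(F)cc1` gives > 40000 nM, also a limit. So the limit of > 40000 nM in this assay, at which 3 of the 3 values shown sit, covers all three values shown, and the three steps between them, a step that the two limits leave unreadable from compound 1 to compound 2, a step that the two limits leave unreadable from compound 1 to compound 3 and a step that the two limits leave unreadable from compound 2 to compound 3, say nothing about how much a change on the amide-type nitrogen in the ring can move the result. Compound 4 `O=C1COc2ccc(-c3cnc(Cl)c(NS(=O)(=O)c4ccc(F)cc4)c3)cc2N1C1CC1` differs from compound 3 by cyclopropyl in place of hydrogen on an amide-type nitrogen in a ring. Among the measured compounds shown here, since no measured step has a readable size, no direction beyond the scatter can be expected for this change in this assay. Compound 4 is therefore expected to stay at the limit, with an estimate of 40000 nM, between 10000 nM and 120000 nM. For the measured compounds named here, the expected step is a number no higher from compound 3 to compound 4 (the limit leaves the size open), which amounts to no step at all.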

Compound 4, half-maximal inhibitory concentration: 8510 nM
Beside the measured number, compound 4's estimate is 4.7-fold (0.67 log units) above it; measured number outside the range, below it.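

The amide-type nitrogen in the ring now proves to be a place where a change can move the result: in this assay, cyclopropyl in place of hydrogen gives an at least 4.7-fold lower number from compound 3 to compound 4 (0.67 log units; beyond the scatter). Cyclopropyl also gives an at least 4.7-fold lower number from compound 2 to compound 4 (0.67 log units; beyond the scatter) in place of 4-fluorophenyl and an at least 4.7-fold lower number from compound 1 to compound 4 (0.67 log units; beyond the scatter) in place of 3-methoxyphenyl, while the steps among the other three compounds cannot be read. Each of the new steps starts from a limit of the assay and not from a number, so only a minimum size can be read: the limit of > 40000 nM in this assay, at which 3 of the 4 values shown sit.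

Going by these compounds, how a methyl, a cyclobutyl or a longer chain on this nitrogen would compare with cyclopropyl stays open. So does whether an amine at the end of such a chain would lower the number further.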